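Propylamino for sulfanyl on the shared core

A few compounds are considered here, and "the series" means these few. Any claim that something is new, unique, unknown or untested is made for them only; others in the source may bear on it.

Compound 3 `OC[C@@H]1O[C@@H](n2c(S)nc3cc(Cl)c(Cl)cc32)[C@H](O)[C@@H]1O` carries a sulfanyl group on its core and in a functional assay on KB cells (Homo sapiens) for inhibition (on this read-out lower numbers stand for stronger inhibition and higher numbers for weaker inhibition), sits at the limit of the assay. In this assay compound 3 reaches only > 100000 nM, a limit and not a number. Compound 1 `CNc1nc2cc(Cl)c(Cl)cc2n1[C@@H]1O[C@@H](CO)[C@@H](O)[C@H]1O`, with methylamino on an aromatic carbon, likewise returns > 100000 nM, a limit. The step that the two limits leave unreadable from compound 1 to compound 3 stays unreadable, as the limit of > 100000 nM in this assay, at which 2 of the 3 values shown sit, blurs both ends. Compound 2 `CCCNc1nc2cc(Cl)c(Cl)cc2n1[C@@H]1O[C@@H](C)[C@@H](O)[C@H]1O` gives 65000 nM in this assay. Compound 4 `CCCNc1nc2cc(Cl)c(Cl)cc2n1[C@@H]1O[C@@H](CO)[C@@H](O)[C@H]1O` differs from compound 3 by propylamino in place of sulfanyl on an aromatic carbon. Within the data shown here, no readable measured step bears on this change, and compound 2 is the only propylamino analogue with a number. The step expected is an at least 1.2-fold lower number from compound 3 to compound 4 (0.09 log units; that floor lies within the scatter), weak inhibition remaining. The estimate for compound 4 is 80000 nM, within 30000 nM to 300000 nM.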

Compound 4, half-maximal inhibitory concentration: > 100000 nM
Compound 4: only a limit was reported; the forecaster's own chance of this, stated with the estimate: 50%; middle value at least 1.2-fold (0.09 log units) from the limit.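

Propylamino in place of sulfanyl on this aromatic carbon brings no readable change, and the steps to compound 4 from compound 1 and compound 3 cannot be read because both ends sit at a limit: the limit of > 100000 nM in this assay, at which 3 of the 4 values shown sit.

Among these compounds, the one readable comparison concerns a different place, hydroxy in place of hydrogen on a saturated chain carbon bound to a saturated ring carbon, and gives an at least 1.5-fold higher number from compound 2 to compound 4 (0.18 log units; that floor lies within the scatter). With propylamino in place, only the compound lacking that hydroxy, compound 2, has a number.

As far as these compounds go, whether a longer chain or a carboxylic acid in place of propylamino would bring a value under the limit remains open.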